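The source may report more compounds than this note shows. Statements on the series, on what has been measured and on what is new or still open speak of the compounds shown alone.

Measured so far in an ADME assay on HFF cells (Homo sapiens) for cytotoxicity, with a stated time of 8 days; a higher number here means that more compound is tolerated, a lower number that less compound is tolerated:
compound 1 `CNc1nc(N)nc2c1ncn2/C=C1/CC1(CO)CO` — 265000 nM
compound 2 `Nc1nc(NC2CCCC2)c2ncn(/C=C3/CC3(CO)CO)c2n1` — > 300000 nM

Compound 2 stands at the top end of what has been seen: its value is a limit of this assay, not a number, and it sits at the limit of > 300000 nM in this assay, at which 1 of the 2 values shown sits. Compound 1 gives a number near that ceiling. Going by the values given here, the one measured step, an at least 1.1-fold higher number from compound 1 to compound 2 (0.05 log units; that floor lies within the scatter), is a change at the same aromatic carbon as the step now followed and stays within the usual scatter.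

Compound 3 `CCCCCCOc1nc(N)nc2c1ncn2/C=C1/CC1(CO)CO` differs from compound 2 as follows: hexyloxy in place of cyclopentylamino on an aromatic carbon. The step from compound 1 to compound 2 already changed the group on this carbon without moving the number beyond the scatter, so no step beyond the scatter is expected in this assay for compound 3 either, the estimated step being an at least 1.2-fold lower number from compound 2 to compound 3 (0.07 log units; that floor lies within the scatter). Compound 3 is expected to give about 250000 nM, between 100000 nM and 300000 nM, with a fair chance that only a limit is reported.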

Compound 3, half-maximal cytotoxic concentration: > 200000 nM
Compound 3: only a limit was reported; the forecaster's own chance of this, stated with the estimate: 45%; the middle value is on the limit's open side.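

Going by these compounds alone, compound 3 gives only a limit in this assay, as does compound 2, and no step from compound 1 or compound 2 to compound 3 can be read. The compounds shown leave open whether hexyloxy on this aromatic carbon differs at all from cyclopentylamino or methylamino in this assay.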